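The source may report more compounds than this note shows. Statements on the series, on what has been measured and on what is new or still open speak of the compounds shown alone.

Within the data shown here, compound 2, `COC(=O)c1c(F)cccc1-c1ccc(CCc2ncc(CC(C)(C)C)n2CCOc2cccc(O)c2)cc1`, is the compound with the highest of the two numbers so far in an assay on cells for agonist activity at Bombesin receptor subtype-3 (Mus musculus), read by HTRF and inositol phosphate accumulation, with a stated time of 1 h (a higher number here means that more compound is needed for the effect, a lower number that less compound is needed), where compound 2 gives 25 nM. Its nearest neighbour is compound 1, `COC(=O)c1c(F)cccc1-c1ccc(CCc2ncc(CC(C)(C)C)n2CCO)cc1`, which in this assay gives 24 nM; the step of a 1.0-fold higher number from compound 1 to compound 2 (0.02 log units; within the scatter) lies within the scatter, so the two compounds are not told apart by these measurements.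

Compound 3, `COC(=O)c1c(F)cccc1-c1ccc(CCc2ncc(CC(C)(C)C)n2CCNS(C)(=O)=O)cc1`, differs from compound 2 by methanesulfonamido in place of 3-hydroxyphenoxy on a saturated chain carbon, two bonds along the chain from an aromatic nitrogen. Among the measured compounds shown here, the only measured step, a 1.0-fold higher number from compound 1 to compound 2 (0.02 log units; within the scatter), changed the same end of the two-carbon chain on the aromatic nitrogen and left the number unchanged, which shows that this end of the chain has so far accepted a large group as readily as a bare hydroxyl. For the measured compounds named here, no measured step, however, covers methanesulfonamido itself, and the two shared compounds do not say whether a sulfonamide at that place behaves like a phenoxy ether. The expected step of a 1.2-fold higher number from compound 2 to compound 3 (0.08 log units; within the scatter) is therefore one of no change beyond the scatter, with a wide range to allow for the unknown group. Compound 3 is estimated to give 30 nM in this assay, between 12 nM and 80 nM.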

Compound 3, half-maximal effective concentration: 7 nM
Estimate against measurement, compound 3: 4.3-fold (0.63 log units) above, outside the stated range (below it).
By their numbers in this assay, from the lowest: compound 3; then compounds 1 and 2 (each within the scatter of the next).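

On a saturated chain carbon, two bonds along the chain from an aromatic nitrogen, the number in this assay turns out to respond to the group placed there: methanesulfonamido in place of 3-hydroxyphenoxy gives a 3.6-fold lower number from compound 2 to compound 3 (0.55 log units; beyond the scatter), and methanesulfonamido in place of hydroxy gives a 3.4-fold lower number from compound 1 to compound 3 (0.54 log units; beyond the scatter). Hydroxy and 3-hydroxyphenoxy could not be told apart at this place, so the two steps agree: of the three groups shown, methanesulfonamido alone stands apart, with less compound needed for the effect. The data offer no explanation of why this group differs from the other two.

Whether an acetamido group, a primary amine, a carboxylic acid or a longer chain ending in methanesulfonamido would give a number like that of compound 3 remains open, so the compounds shown do not tell which part of the methanesulfonamido group goes with the lower number. From the compounds shown here alone, it also remains open whether the same change would give a step of similar size if the methyl ester or the neopentyl-bearing part of the shared core were altered.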